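The source may report more compounds than this note shows. Statements on the series, on what has been measured and on what is new or still open speak of the compounds shown alone.

Measured in a functional assay on A549 cells (Homo sapiens) for cytotoxicity, read by WST assay, with a stated time of 24 h; on this read-out higher numbers stand for weaker inhibition and lower numbers for stronger inhibition:
compound 1 `COc1ccc(Cn2cc(/C=C(\C#N)C(=O)c3c[nH]c4cc(OC)ccc34)c3ccccc32)cc1` gives 37400 nM
compound 2 `COc1ccc2c(/C=C(\C#N)C(=O)c3c[nH]c4cc(OC)ccc34)c[nH]c2c1` gives 1900 nM
compound 3 `COc1ccc2c(C(=O)/C(C#N)=C/c3c[nH]c4cc(F)ccc34)c[nH]c2c1` gives 2400 nM

Compound 3 stands second highest of these three numbers in this assay: compound 2 is nearest, compound 1 furthest, that gap lying beyond the scatter. Next in the series is compound 4 `COc1ccc2c(C(=O)/C(C#N)=C/c3c[nH]c4ccccc34)c[nH]c2c1`, differing from compound 3 by hydrogen in place of fluoro on an aromatic carbon. Within the data shown here, one measured step concerns the same aromatic carbon, a 1.3-fold higher number from compound 2 to compound 3 (0.10 log units; within the scatter), where one group replaced another without moving the number beyond the scatter. Among the measured compounds shown here, no measured compound here carries hydrogen at that carbon, so the expectation rests on that single step alone. For compound 4 in this assay the step of no change at the digits printed from compound 3 to compound 4 (within the scatter) is therefore expected to remain within the scatter. Compound 4 is estimated at 2400 nM, within a range of 1000 nM to 6000 nM.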

Compound 4, half-maximal inhibitory concentration: 6400 nM
Compound 4: the middle estimate sits 2.7-fold (0.43 log units) below what was measured; measured number outside the range, above it.
By their numbers in this assay, from the lowest: compounds 2 and 3 (each within the scatter of the next); then compound 4; then compound 1.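

In this assay the carbon bearing hydrogen stands apart at this position: hydrogen in place of fluoro gives a 2.7-fold higher number from compound 3 to compound 4 (0.43 log units; beyond the scatter) and hydrogen in place of methoxy gives a 3.4-fold higher number from compound 2 to compound 4 (0.53 log units; beyond the scatter) so either substituent goes with a lower number than hydrogen across these three compounds. On the aromatic nitrogen, hydrogen in place of 4-methoxybenzyl gives a 5.8-fold lower number from compound 1 to compound 4 (0.77 log units; beyond the scatter) with the carbon substituent absent in both compounds. Nothing on hand accounts for these steps. Still open, on these data alone, is how other groups at that carbon, such as chloro, an amine or a carboxylic acid, would compare with fluoro and methoxy. Also open, as far as these compounds go, is whether the step at the nitrogen holds when fluoro or methoxy occupies that carbon.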